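A few compounds are considered here, and "the series" means these few. Any claim that something is new, unique, unknown or untested is made for them only; others in the source may bear on it.

Two compounds with a shared core carry a long saturated chain ending in an amine. Compound 1 `CN(C)CCCCCCOc1ccc2oc(-c3ccccc3)cc(=O)c2c1` gives 335 nM in an assay on isolated protein (Cavia porcellus) with Sigma non-opioid intracellular receptor 1 (Homo sapiens) as the target, read by radioligand binding (on this read-out higher numbers stand for weaker inhibition and lower numbers for stronger inhibition), the higher of the two numbers measured. Compound 2 `O=c1cc(C2CCCCC2)oc2ccc(OCCCCCCN3CCCCC3)cc12` gives 32 nM in this assay, a lower number that lies beyond the usual scatter; compound 2 differs from compound 1 in more than one place, so the two values alone cannot be traced to a single change.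

Compound 3 `NCCCCCCOc1ccc2oc(-c3ccccc3)cc(=O)c2c1` is the one not yet measured. It differs from compound 1 in one way: amino in place of dimethylamino on a saturated chain carbon, six bonds along the chain from an oxygen on an aromatic ring. Among the measured pairs no single change of this kind has been followed, so the expectation rests on general experience with such chain-end amines. The step is expected to raise the number, by about a 3.0-fold higher number from compound 1 to compound 3 (0.47 log units; beyond the scatter). Compound 3 is therefore expected to give 1000 nM in this assay, within a range from 300 nM to 3500 nM.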

Compound 3, half-maximal inhibitory concentration: 3700 nM
The estimate for compound 3 lay 3.7-fold (0.57 log units) below the measured number, outside the stated range (above it).
By their numbers in this assay, from the lowest: compound 2; then compound 1; then compound 3.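

With the shared core and the chain unchanged, amino in place of dimethylamino, on a saturated chain carbon six bonds along the chain from an oxygen on an aromatic ring, gives an 11-fold higher number from compound 1 to compound 3 (1.04 log units; beyond the scatter) in this assay and so produces a large step, beyond the scatter. Within the data shown here, this is the first single change that can be followed here, and it shows that the number responds strongly to what the chain-end nitrogen carries, with the two methyl groups counting for much in this pair. Nothing available here accounts for the size of this step.

Still open, going by these compounds, is how the step builds up: methylamino would show what one methyl group contributes, and diethylamino whether larger groups on the nitrogen lower the number further. On these data alone, whether the same change has a similar effect on a shorter chain also remains unknown.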